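Swapping phenoxy for dimethylamino in a growth-inhibition assay

The compounds below may be only part of what the source reports. "The series", "measured", "known", "first", "only" and "open" are said of these compounds alone.

Compound 1 `Cc1ccc(S/C(=C/c2ccc(C)s2)C(=O)c2ccc(Br)cc2)cc1`: > 100000 nM
Compound 2 `Cc1ccc(S/C(=C/c2ccc(Oc3ccccc3)cc2)C(=O)c2ccc(Br)cc2)cc1`: 1000 nM

Within the data shown here, only two compounds have been measured so far in a functional assay on DU-145 cells (Homo sapiens) for inhibition, read by trypan blue exclusion, with a stated time of 96 h (a higher number here means a weaker inhibitor of growth, a lower number a stronger inhibitor of growth), and just one of them has a true number. Compound 1 shows > 100000 nM, which is a limit of the assay and not a number. Compound 2, at 1000 nM, therefore provides the only exact reference point.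

The next compound is compound 3 `Cc1ccc(S/C(=C/c2ccc(N(C)C)cc2)C(=O)c2ccc(Br)cc2)cc1`. It keeps the shared core of compound 2 but carries dimethylamino in place of phenoxy on an aromatic carbon. Among the measured compounds shown here, no measured step between two closely matched compounds shows what such a swap does, so any forecast here is loose.

For the measured compounds named here, the limit seen for compound 1 shows only that a compound of this kind can fail to give a number in this assay. A moderate loss of growth inhibition seems the likeliest outcome, with a result close to compound 2 also possible. The expected change is a 4.0-fold higher number from compound 2 to compound 3 (0.60 log units; beyond the scatter). For compound 3 the estimated value is 4000 nM, with an expected range of 500 nM to 30000 nM.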

Compound 3, concentration for 50% growth inhibition: > 100000 nM
Compound 3 gave a limit, no number (the forecaster's own chance of this, stated with the estimate: 20%); at least 25-fold (1.39 log units) between middle value and limit.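

In this assay, among these compounds, dimethylamino in place of phenoxy on an aromatic carbon, para to a large group, gives an at least 100-fold higher number from compound 2 to compound 3 (2.00 log units; beyond the scatter); this is the first matched step at this position, and it shows that growth inhibition can depend strongly on the group placed there. From the compounds shown here alone, compound 3 gives > 100000 nM, which is a limit of the assay and not a number, so the true size of the step stays unknown and the printed size is only the smallest it can be. The step from compound 1 to compound 3 cannot be read, as both compounds give limits: the limit of > 100000 nM in this assay, at which 2 of the 3 values shown sit.

The compounds shown leave open which part of phenoxy counts, its oxygen or its six-membered aromatic ring of carbon only. A methoxy group on the same carbon would keep the oxygen without the ring, while a phenylamino group would keep the ring with a nitrogen in place of the oxygen, so the two together could begin to separate these parts.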